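The source may report more compounds than this note shows. Statements on the series, on what has been measured and on what is new or still open speak of the compounds shown alone.

Within the data shown here, compound 1 `O=C(Cc1cccnc1)c1cc2c(O)cccc2[nH]1` is the only compound here with a numeric result: in an assay on isolated protein for inhibition of Indoleamine 2,3-dioxygenase 1 (Homo sapiens), read by spectrophotometry (a higher number here means a weaker inhibitor, a lower number a stronger inhibitor), compound 1 gives 83000 nM, a weak inhibition. Compound 2 `COc1ccc2[nH]c(C(=O)Cc3cccnc3)cc2c1OCc1ccccc1` is recorded in this assay simply as "not active" (no number reported), with no number. Compound 3 `O=C(Cc1cccnc1)c1cc2ccccc2[nH]1` is the next case. It differs from compound 1 by a single change: hydrogen in place of hydroxy on an aromatic carbon. Among the measured compounds shown here, with only one number available, no measured step guides the expectation, so a modest loss of inhibition, beyond the usual scatter, is expected for a 1.8-fold higher number from compound 1 to compound 3 (0.26 log units; within the scatter). For compound 3 the estimate in this assay is 150000 nM, within a range from 40000 nM to 600000 nM.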

Compound 3, half-maximal inhibitory concentration: 65000 nM
Estimate against measurement, compound 3: 2.3-fold (0.36 log units) above; measured number inside the range.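

In this assay, putting hydrogen in place of hydroxy on this aromatic carbon gives a 1.3-fold lower number from compound 1 to compound 3 (0.11 log units; within the scatter), so removing the hydroxy leaves no measurable change in inhibition. This position therefore tolerates the loss of hydroxy, although the inhibition remains weak with either group. No other data here help to explain this result. On these data alone, it remains open whether an amine or a carboxylic acid on this carbon would shift the number beyond the scatter. Compound 2 differs from compound 1 in more than one place, so it cannot settle this question.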